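A few compounds are considered here, and "the series" means these few. Any claim that something is new, unique, unknown or untested is made for them only; others in the source may bear on it.

Measured so far:

Compound 1, `CN(C)CCC(NC(=O)/C=C/c1ccc(C(F)(F)F)cc1)c1ccc2ccccc2c1`: 117%
Compound 2, `Cc1ccc(C(CCN(C)C)NC(=O)CCc2ccccc2)cc1`: 73%
Compound 3, `CN(C)CCC(NC(=O)/C=C/c1ccccc1)c1ccc2ccccc2c1`: 116%

All three were tested in a functional assay on NIH3T3 cells for agonist activity at Urotensin-2 receptor (Homo sapiens), with a stated time of 5 days; a higher number here means a larger maximal response, a lower number a smaller maximal response. Compound 3 and compound 1 share one core and differ by a single change, (trifluoromethyl in place of hydrogen on an aromatic carbon), and the step it made was a number 1 percentage points higher from compound 3 to compound 1 (within the scatter). Compound 2 is built on a different core, and the difference between the two cores is not broken down here. Its maximal response is lower than that of compound 3 and of compound 1, and both gaps lie beyond the usual scatter.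

Compound 4, `Cc1ccc(C(CCN(C)C)NC(=O)CCc2ccc(C(F)(F)F)cc2)cc1`, is not yet measured. It differs from compound 2 by trifluoromethyl in place of hydrogen on an aromatic carbon, the same change as from compound 3 to compound 1, at the same kind of place. Since that earlier change gave a step of a number 1 percentage points higher from compound 3 to compound 1 (within the scatter), the step from compound 2 to compound 4 in this assay is expected to be of similar size, namely a number 2 percentage points higher from compound 2 to compound 4 (within the scatter). On that basis compound 4 is estimated at 75%, with a plausible range from 55% to 95%.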

Compound 4, largest response reached (reported as efficacy), in percent of the reference or control that the assay uses: 60%
Estimate against measurement, compound 4: 15 percentage points above; the range from low to high includes it.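

In this assay, putting trifluoromethyl in place of hydrogen on an aromatic carbon gave a number 13 percentage points lower from compound 2 to compound 4 (beyond the scatter), while the same change on the other core gave a number 1 percentage points higher from compound 3 to compound 1 (within the scatter). One step lies beyond the scatter and the other within it, which might suggest that the core decides the outcome, but set side by side the two steps cannot be told apart: the same change on two cores in this assay, a number 1 percentage points higher (within the scatter) from compound 3 to compound 1 and a number 13 percentage points lower (beyond the scatter) from compound 2 to compound 4, 14 percentage points apart, within the scatter of two such steps. Among the compounds shown here, the data therefore do not show that the change behaves differently on the two cores, and with only one pair per core they do not establish that its effect carries over reliably from one core to the other either.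

From the compounds shown here alone, whether a smaller or different group in that place, such as a chlorine, a methoxy group or a nitrile, would lower the maximal response on the core of compound 2 remains open. Also open is whether any step seen here would hold for a third core, or for the potency of these compounds rather than their maximal response.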